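Swapping the sulfonyl aryl group in a serotonin receptor series

This account rests on a few compounds, and the source may have more. Where it says the series, first, only, none or still open, it means among the compounds named here.

Compound 1, `COc1ccc(S(=O)(=O)NCCN2CCC(CCC(=O)c3cc(Cl)c(N)cc3OC)CC2)cc1`, was tested in an assay on HEK293 cells for displacement of a labelled ligand from 5-hydroxytryptamine receptor 6 (Homo sapiens), with a stated time of 60 min, tested at 0.01 uM, in the presence of a further agent that is not named here (a higher number here means a stronger effect of the compound at the concentration tested, a lower number a weaker effect), and gave 36%. This is the higher of the two numbers seen so far. Among the compounds with values here, compound 2, `COc1ccc(S(=O)(=O)CCCN2CCC(CCC(=O)c3cc(Cl)c(N)cc3OC)CC2)cc1`, gives 10% in this assay, a number that lies well under that of compound 1 and beyond the usual scatter of such measurements; the two structures differ in more than one place, so no single step is drawn between them. Compound 3, `COc1cc(N)c(Cl)cc1C(=O)CCC1CCN(CCNS(=O)(=O)c2cc(Br)c(N)c(Br)c2)CC1`, has not yet been measured. It differs from compound 1 in one place: 4-amino-3,5-dibromophenyl in place of 4-methoxyphenyl on a sulfonyl sulfur. Within the data shown here, no measured pair shows the effect of this exchange, so the size of the step is unknown. The expectation is that the step of a number 1 percentage points lower from compound 1 to compound 3 (within the scatter) stays within the scatter, with no clear direction. Compound 3 is therefore estimated at 35% in this assay, with a plausible range from 10% to 62%.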

Compound 3, a percentage reported as inhibition, at one concentration (the size of the read-out at that concentration, not a potency): 52%
The estimate for compound 3 lay 17 percentage points below the measured number; the measured number falls inside the stated range.
By their numbers in this assay, from the lowest: compound 2; then compound 1; then compound 3.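

In this assay, within the data shown here, exchanging 4-methoxyphenyl for 4-amino-3,5-dibromophenyl on a sulfonyl sulfur gives a number 16 percentage points higher from compound 1 to compound 3 (beyond the scatter), a modest step, and the first single change in this set whose effect can be read. It shows that the 4-methoxyphenyl group is not needed at this place for the read-out at the concentration tested, and that a quite differently substituted phenyl ring can give a higher number. No measurement shown here explains this rise.

On these data alone, the exchange removes the methoxy group and brings in an amine and two bromine atoms at once, so the share of each remains open, and a simple 4-aminophenyl or 3,5-dibromophenyl group would be needed to separate them. As far as these compounds go, since the read-out is taken at one concentration, how far the step carries over to potency also remains open.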